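The source may report more compounds than this note shows. Statements on the series, on what has been measured and on what is new or still open speak of the compounds shown alone.

Measured compounds in a functional assay on PANC-1 cells (Homo sapiens) for inhibition, read by MTT assay, with a stated time of 24 h, tested at 10 uM; on this read-out higher numbers stand for more inhibition at the one concentration tested (going by the name of the read-out) and lower numbers for less inhibition:
- compound 1 `COc1ccc(NC(=O)Oc2cc(=O)n(CCCO)c3c2CC(CC=C(C)C)C(C)(C)C3)cc1`: 3.7%
- compound 2 `CC(C)=CCC1Cc2c(OC(=O)Nc3cccc(C(F)(F)F)c3)cc(=O)n(CCCO)c2CC1(C)C`: 54.3%
- compound 3 `COc1ccc(NC(=O)Oc2cc(=O)n(CCCO)c3c2CC(C/C=C(\C)CCC=C(C)C)C(C)(C)C3)cc1`: 64.1%

Compound 3 gives the largest of the three numbers, but compound 2 lies within the usual scatter of it, so the two cannot be ordered; only compound 1 sits clearly apart, with a number 60.4 percentage points higher from compound 1 to compound 3 (beyond the scatter).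

Compound 4 `CC(C)=CCC/C(C)=C/CC1Cc2c(OC(=O)Nc3ccc(F)c(Cl)c3)cc(=O)n(CCCO)c2CC1(C)C` is not yet measured. It differs from compound 3 in one place: 3-chloro-4-fluorophenyl in place of 4-methoxyphenyl on an amide-type nitrogen.

For the measured compounds named here, one measured step bears on this change. On the core of compound 1, exchanging the same 4-methoxyphenyl for another substituted phenyl gave a number 50.6 percentage points higher from compound 1 to compound 2 (beyond the scatter), a large gain. Compound 4 carries both that kind of aryl exchange and the 3-methylbut-2-en-1-yl chain that distinguishes compound 3 from compound 1. Whether the two gains add is not shown by any measured pair, and compound 3 already stands high, so the room for a further rise is limited.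

For compound 4 a modest rise in this assay is expected, a number 7.9 percentage points higher from compound 3 to compound 4 (within the scatter), which may fall within the scatter. The estimate for compound 4 is 72%, with a range from 52% to 90%.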

Compound 4, a percentage reported as inhibition, at one concentration (the size of the read-out at that concentration, not a potency): 25%
Compound 4: the middle estimate sits 47 percentage points above what was measured; the measured number lies below the stated range.
By their numbers in this assay, from the lowest: compound 1; then compound 4; then compounds 2 and 3 (each within the scatter of the next).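

In this assay, for the compounds shown here, replacing 4-methoxyphenyl on the amide-type nitrogen does not always raise the number: 3-chloro-4-fluorophenyl in its place gives a number 39.1 percentage points lower from compound 3 to compound 4 (beyond the scatter), whereas the only earlier exchange at this nitrogen gave a number 50.6 percentage points higher from compound 1 to compound 2 (beyond the scatter). The two exchanges differ in the entering aryl group and in the chain they sit with, so the direction of a change at this nitrogen is not constant across the compounds shown, and on the chain of compound 3 the 4-methoxyphenyl group gives the higher number of the pair. No measurement at hand accounts for this reversal.

Still open, from the compounds shown here alone, is how 3-(trifluoromethyl)phenyl reads on the chain of compound 3, which would separate the role of the aryl group from that of the chain. Also open, going by these compounds, is how an aryl ring carrying an amine or a carboxylic acid reads at this nitrogen.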